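Estimating Compound 4 from Its Methoxyphenyl Neighbour

The source may report more compounds than this note shows. Statements on the series, on what has been measured and on what is new or still open speak of the compounds shown alone.

Three measured compounds share one core and differ only in the aryl group on an amide-type nitrogen whose other neighbour is a carbonyl carbon. Compound 1 `O=C(Nc1ccccc1)Nc1cccc(CNc2nccnc2Cl)c1` carries a plain phenyl, and in a functional assay on T-24 cells (Homo sapiens) for antiproliferative activity, read by MTT assay, with a stated time of 48 h (on this read-out higher numbers stand for weaker inhibition and lower numbers for stronger inhibition), compound 1 gives 19800 nM. Compound 2 `COc1ccc(NC(=O)Nc2cccc(CNc3nccnc3Cl)c2)cc1` bears a 4-methoxyphenyl; in this assay compound 2 gives 9820 nM, the second highest of the three numbers, with compound 3 nearest and compound 1 furthest. Compound 3 `Cc1ccc(NC(=O)Nc2cccc(CNc3nccnc3Cl)c2)cc1C` carries a 3,4-dimethylphenyl, and in this assay compound 3 gives 8930 nM. The steps among them are small: a 2.0-fold lower number from compound 1 to compound 2 (0.30 log units; within the scatter), a 2.2-fold lower number from compound 1 to compound 3 (0.35 log units; beyond the scatter), and a 1.1-fold lower number from compound 2 to compound 3 (0.04 log units; within the scatter).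

Compound 4 `Cc1ccc(NC(=O)Nc2cccc(CNc3nccnc3Cl)c2)cc1Cl` has not yet been measured. Its difference from compound 2 is 3-chloro-4-methylphenyl in place of 4-methoxyphenyl on an amide-type nitrogen. The step that bears most directly on this change is a 1.1-fold lower number from compound 2 to compound 3 (0.04 log units; within the scatter), where the same 4-methoxyphenyl was exchanged for another disubstituted phenyl with hardly any shift, while a 2.2-fold lower number from compound 1 to compound 3 (0.35 log units; beyond the scatter) shows that such ring substitution brought only a modest gain over phenyl. The expected step is therefore a 1.3-fold lower number from compound 2 to compound 4 (0.12 log units; within the scatter) in this assay, lower in number if anything, but not beyond the scatter. The estimate for compound 4 in this assay is 7500 nM, with a range from 3500 nM to 16000 nM.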

Compound 4, half-maximal inhibitory concentration: 7390 nM
For compound 4 the middle estimate is 1.0-fold (0.01 log units) above the measured one; the range from low to high includes it.
By their numbers in this assay, from the lowest: compounds 4, 3, 2 and 1 (each within the scatter of the next, the first and the last beyond it).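

In this assay, compound 4 is the only one of the four with a chlorine on the aryl group at this amide-type nitrogen, and a 1.2-fold lower number from compound 3 to compound 4 (0.08 log units; within the scatter) shows that chloro in place of methyl on an aromatic carbon stays within the scatter. The whole exchange of aryl groups, a 1.3-fold lower number from compound 2 to compound 4 (0.12 log units; within the scatter) likewise, leaves 4-methoxyphenyl, with its hydrogen-bond acceptor, and 3-chloro-4-methylphenyl, with none, indistinguishable on this read-out. Against the plain phenyl, the new group gives a 2.7-fold lower number from compound 1 to compound 4 (0.43 log units; beyond the scatter) and so joins compound 3 in standing beyond the scatter from compound 1, whereas compound 2 stays within it, even though compounds 2, 3 and 4 cannot be separated from one another.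

The compounds shown leave open how this aryl group would read with an amine or a carboxylic acid in place of these small groups, or with a longer chain such as butoxy, and what any change elsewhere in the shared core would do. Nothing shown explains why the steps at this position stay so small.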